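Trifluoromethyl for Methyl on the Pyrazole of Compound 3

The source may report more compounds than this note shows. Statements on the series, on what has been measured and on what is new or still open speak of the compounds shown alone.

Three analogues have been measured in a functional assay on CHO cells for antagonist activity at sphingosine 1-phosphate receptor 2 (Homo sapiens), read by scintillation counting and GTPgammaS binding, with a stated time of 4 h, in the presence of a further agent that is not named here; a lower number here means a stronger inhibitor, a higher number a weaker inhibitor. Compound 1 `Cc1cc(CNC(=O)c2cc3c(Cl)nc(Cl)cc3[nH]2)ncc1-c1cn(C)nc1C` gives 1.3 nM, and compound 2 `Cc1cc(CNC(=O)Nc2cc(Cl)nc(Cl)c2)ncc1-c1cn(C)nc1C` gives 0.77 nM. Compound 3 `CCOc1cc(NC(=O)NCc2cc(C)c(-c3cn(C)nc3C)cn2)cc(Cl)n1` gives 0.32 nM, the lowest of the three numbers: the step of a 2.4-fold lower number from compound 2 to compound 3 (0.38 log units; beyond the scatter) lies beyond the scatter, and compound 1 lies furthest from compound 3. Compound 4 `CCOc1cc(NC(=O)NCc2cc(C)c(-c3cn(C)nc3C(F)(F)F)cn2)cc(Cl)n1` differs from compound 3 by trifluoromethyl in place of methyl on an aromatic carbon. For the measured compounds named here, the single measured step, from compound 2 to compound 3, exchanges an ethoxy for a chloro and does not touch the 1,3-dimethyl-1H-pyrazol-4-yl group, so no measured step bears on this change. Compound 4 is therefore expected to move little, a 1.6-fold higher number from compound 3 to compound 4 (0.19 log units; within the scatter), at most modestly in either direction. The value of compound 4 in this assay is estimated at 0.5 nM, within 0.15 nM to 1.6 nM.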

Compound 4, half-maximal inhibitory concentration: 22 nM
Compound 4: middle estimate off by 44-fold (1.64 log units), on the low side, and the stated range ends below it.
By their numbers in this assay, from the lowest: compound 3; then compounds 2 and 1 (each within the scatter of the next); then compound 4.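

In this assay, trifluoromethyl in place of methyl, on the aromatic carbon next to the ring nitrogen and next to the ring atom that bears a large group, gives a large loss (a 69-fold higher number from compound 3 to compound 4 (1.84 log units; beyond the scatter)). For the compounds shown here, all the earlier compounds carry the 1,3-dimethyl-1H-pyrazol-4-yl group, so this is the first sign that the position responds strongly to change. No evidence at hand accounts for the loss.

The compounds shown leave open whether hydrogen, chloro, ethyl or cyclopropyl on this carbon would keep the number of compound 3. They also leave open whether the same exchange would cost as much in compound 2.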